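Swapping Methyl for Cyclopentyl on the Ring Amine

A few compounds are considered here, and "the series" means these few. Any claim that something is new, unique, unknown or untested is made for them only; others in the source may bear on it.

Measured in an assay on HEK293 cells for binding affinity to 5-hydroxytryptamine receptor 7 (Homo sapiens), read by radioligand binding; on this read-out lower numbers stand for stronger inhibition and higher numbers for weaker inhibition:
compound 1 `CN1CCCN(CCn2ccc3ccc(Br)cc32)CC1` gives 31 nM
compound 2 `CCc1ccc2ccn(CCN3CCCN(C)CC3)c2c1` gives 166 nM

Compound 1 holds the lower of the two numbers. Among the measured compounds shown here, the only measured step, a 5.4-fold higher number from compound 1 to compound 2 (0.73 log units; beyond the scatter), comes from an ethyl in place of a bromo on an aromatic carbon.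

Compound 3 `Brc1ccc2ccn(CCN3CCCN(C4CCCC4)CC3)c2c1` differs from compound 1 by cyclopentyl in place of methyl on an amine nitrogen in a ring. That change sits on the ring amine, not on the aromatic carbon, so the measured step offers no direct guide; the bromo of compound 1 is kept. With nothing to point either way, only a small shift in this assay, possibly within the scatter, is expected. Compound 3 is estimated at 60 nM, with a range of 12 nM to 350 nM, which means an expected step of a 1.9-fold higher number from compound 1 to compound 3 (0.29 log units; within the scatter).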

Compound 3, inhibition constant: 10 nM
Beside the measured number, compound 3's estimate is 6.0-fold (0.78 log units) above it; measured number outside the range, below it.
By their numbers in this assay, from the lowest: compound 3; then compound 1; then compound 2.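

In this assay, cyclopentyl on the amine nitrogen in the ring brings a 3.1-fold lower number from compound 1 to compound 3 (0.49 log units; beyond the scatter). So this nitrogen accepts a group carrying its own ring in place of methyl, with a gain rather than a loss. Among the compounds shown here, the earlier step changed only an aromatic carbon, so this is the first sign that the ring amine also moves the number, though nothing here speaks to the reason. From the compounds shown here alone, whether the gain depends on the ring of cyclopentyl or on added carbon alone stays open; isopropyl or cyclohexyl on the same nitrogen would help separate the two. Also open, going by these compounds, is whether the gain would hold with ethyl in place of the bromo.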